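Fluorine on the central ring of compound 1

This account rests on a few compounds, and the source may have more. Where it says the series, first, only, none or still open, it means among the compounds named here.

Compound 1, `O=C(Nc1ccc(Oc2ccnc3[nH]ccc23)cc1)c1nccc(-c2cccc(Cl)c2)n1`: in a functional assay on MCF7 cells (Homo sapiens) for cytotoxicity, read by MTT assay, with a stated time of 72 h (on this read-out higher numbers stand for weaker inhibition and lower numbers for stronger inhibition), compound 1 gives 10200 nM.
Compound 2, `O=C(Nc1ccc(Oc2ccnc3[nH]ccc23)cc1)c1nccc(-c2ccc(F)cc2)n1`: in this assay compound 2 is reported as "not active" (no number reported), with no number attached.

Compound 1 holds the only number shown in this assay; the one other entry, compound 2, carries no number, so compound 1 cannot be placed against it beyond the fact that compound 1 alone was given a value. Compound 3, `O=C(Nc1ccc(Oc2ccnc3[nH]ccc23)c(F)c1)c1nccc(-c2cccc(Cl)c2)n1`, differs from compound 1 in one place: fluoro in place of hydrogen on an aromatic carbon of a six-membered aromatic ring of carbon only, ortho to a large group and meta to a large group. Among the measured compounds shown here, no step between two measured compounds is available to show what such a change does here, and compound 1 and compound 2 differ on another ring. For the measured compounds named here, the only anchor is the value of compound 1 in this assay, 10200 nM. The step is expected to be small, a 1.3-fold lower number from compound 1 to compound 3 (0.11 log units; within the scatter), no larger than the scatter in either direction. Compound 3 is accordingly estimated at 8000 nM in this assay, within 3000 nM to 25000 nM.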

Compound 3, half-maximal inhibitory concentration: 1580 nM
Estimate against measurement, compound 3: 5.1-fold (0.70 log units) above; the whole stated range lies above it.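

In this assay, the carbon ortho to a large group and meta to a large group proves responsive to substitution: fluoro in place of hydrogen, a change of 1 heavy atom, gives a 6.5-fold lower number from compound 1 to compound 3 (0.81 log units; beyond the scatter). This is the first step shown between two measured compounds that differ in one place, and it shows that this hydrogen of compound 1 can be replaced without loss of the measured effect on these cells; in this pair, the number falls instead. Nothing measured here accounts for the size or direction of the step, so the result stands as an observation without an explanation.

The compounds shown rest on this single pair, so they do not tell whether a chloro, methyl, methoxy or amine group at the same carbon would move the number in the same direction, or whether fluoro on another carbon of this ring would do the same. They also leave open whether the step carries over to a compound without the chloro group of compound 1, since this fluoro change is shown only on that one background.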